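Chloro to Bromo on the Shared Core

This account rests on a few compounds, and the source may have more. Where it says the series, first, only, none or still open, it means among the compounds named here.

Compound 1 `COc1ccccc1Sc1c[nH]c2ccc(Cl)cc12` has been measured in an assay on isolated protein for inhibition of Indoleamine 2,3-dioxygenase 1 (Homo sapiens), read by HPLC, with a stated time of 60 min, in the presence of a further agent that is not named here (a higher number here means a weaker inhibitor, a lower number a stronger inhibitor), where compound 1 gives 17500 nM. Of the two plain numbers shown, this is the lowest. Compound 3 `Cc1ccccc1Sc1c[nH]c2ccc(Cl)cc12` gives 21000 nM in this assay, and the step of a 1.2-fold higher number from compound 1 to compound 3 (0.08 log units; within the scatter) lies within the scatter, so neither compound can be called the stronger inhibitor. Compound 2 `COC(=O)c1[nH]c2ccc(Cl)cc2c1Sc1ccccc1OC` reaches only a limit of this assay, > 200000 nM, which is a limit and not a number. The step of an at least 11-fold higher number from compound 1 to compound 2 (1.05 log units; beyond the scatter) is large, as the limit of > 200000 nM in this assay, at which 1 of the 3 values shown sits, shows.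

Compound 4 `COc1ccccc1Sc1c[nH]c2ccc(Br)cc12` is not yet measured. It differs from compound 1 in one place: bromo in place of chloro on an aromatic carbon. Neither measured step touches this position. The step of a 1.2-fold higher number from compound 1 to compound 3 (0.08 log units; within the scatter) exchanges a group on a different ring and stays within the scatter, while the step of an at least 11-fold higher number from compound 1 to compound 2 (1.05 log units; beyond the scatter) adds a methoxycarbonyl elsewhere and is large. For the measured compounds named here, with no measured step at the changed position, the swap of bromo for chloro is expected to leave the number close to that of compound 1, so that the step of a 1.2-fold lower number from compound 1 to compound 4 (0.07 log units; within the scatter) is expected to fall within the scatter. The estimate for compound 4 in this assay is 15000 nM, with a range from 6000 nM to 40000 nM.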

Compound 4, half-maximal inhibitory concentration: 24000 nM
For compound 4 the middle estimate is 1.6-fold (0.20 log units) below the measured one, within the range that was stated.
By their numbers in this assay, from the lowest: compounds 1, 3 and 4 (each within the scatter of the next). At a limit, above all of these: compound 2.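

For the compounds shown here, the step of a 1.4-fold higher number from compound 1 to compound 4 (0.14 log units; within the scatter) in this assay is the first measured step at this position, since compounds 1, 2 and 3 all carry chloro there and so could say nothing about it. It shows that, in this one pair, chloro and bromo on this aromatic carbon of the shared core cannot be told apart: the two compounds sit within the usual spread of repeat measurements, and neither can be called the stronger inhibitor. Both groups count as one heavy atom with no hydrogen-bond donor or acceptor, and no measured property shown here bears on this pair, so the data give no reason for the result.

With only two halogens at this position, what the compounds shown leave open is whether the number would stay in the same region with a quite different group there, such as an amine, a carboxylic acid or a longer chain, or with plain hydrogen. From the compounds shown here alone, it also remains open whether bromo would read the same way alongside the methyl of compound 3 or the methoxycarbonyl of compound 2.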